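The compounds below may be only part of what the source reports. "The series", "measured", "known", "first", "only" and "open" are said of these compounds alone.

Measured compounds, with what each gives in an ADME assay on HEK293 cells (Homo sapiens) for cytotoxicity, read by resazurin assay, with a stated time of 48 h; on this read-out lower numbers stand for higher toxicity in this test and higher numbers for lower toxicity in this test:

- compound 1 `O=S(=O)(Nc1ccc(-c2nc3ccccc3o2)cc1)c1cccc(Cl)c1`: compound 1 gives only a limit, > 100000 nM
- compound 2 `O=S(=O)(Nc1ccc(-c2nc3ccccc3o2)cc1)c1ccccc1O`: compound 2 gives only a limit, > 100000 nM
- compound 3 `Cc1cccc(S(=O)(=O)Nc2ccc(-c3nc4ccccc4o3)cc2)c1`: compound 3 gives only a limit, > 100000 nM

None of the three values is a number; each is the limit of this assay. Compound 3 therefore stands nowhere within the series that could be ordered: the three steps among the measured compounds, a step that the two limits leave unreadable from compound 1 to compound 2, a step that the two limits leave unreadable from compound 1 to compound 3 and a step that the two limits leave unreadable from compound 2 to compound 3, are all unreadable, since (the limit of > 100000 nM in this assay, at which 3 of the 3 values shown sit).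

Compound 4 `O=S(=O)(Nc1ccc(-c2nc3ccccc3o2)cc1)c1ccc(Cl)s1` differs from compound 3 by 5-chlorothiophen-2-yl in place of 3-methylphenyl on a sulfonyl sulfur. Among the measured compounds shown here, no measured step touches the sulfonyl substituent in a way that can be sized, and nothing speaks against the limit being reached again. The expectation for a step that the limit leaves unreadable from compound 3 to compound 4 is thus no readable step beyond the scatter. Compound 4 is expected to sit at or near the limit, with an estimate of 150000 nM in this assay, within 60000 nM to 400000 nM, and with a high chance that only a limit and no number is reported.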

Compound 4, half-maximal cytotoxic concentration: > 100000 nM
Compound 4 ended at the assay's limit (the forecaster's own chance of this, stated with the estimate: 80%); the middle value is on the limit's open side.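

Compound 4 gives only a limit in this assay, as do compound 1, compound 2 and compound 3, so none of the steps to compound 4 can be read: the limit of > 100000 nM in this assay, at which 4 of the 4 values shown sit.

The compounds shown leave open whether any group on the sulfonyl sulfur gives a half-maximal cytotoxic concentration that can be stated as a number, and so how these groups rank against one another.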